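Swapping 3,4-difluorophenyl for 2-hydroxyphenyl on a shared core

The source may hold more compounds than are shown below. What is called first, only, known or untested is meant among the compounds shown, and "the series" means these compounds.

Of the compounds shown here, three built on one shared core have been tested so far, each differing only in the group on a carbonyl carbon. Compound 1 `Cc1ccc(S(=O)(=O)N[C@@H](CC(=O)NC(C)(C)C)C(=O)NCCNC(=O)c2ccccc2)cc1`, with a plain phenyl there, reads > 11000 nM in an ADME assay on HepG2 cells (Homo sapiens) for cytotoxicity (a lower number here means that less compound is needed, a higher number that more compound is needed for the effect), which is a limit of the assay and not a number. Compound 2 `Cc1ccc(S(=O)(=O)N[C@@H](CC(=O)NC(C)(C)C)C(=O)NCCNC(=O)c2c(O)cccc2F)cc1` reads > 11000 nM, again a limit. Compound 3 `Cc1ccc(S(=O)(=O)N[C@@H](CC(=O)NC(C)(C)C)C(=O)NCCNC(=O)c2ccc(F)c(F)c2)cc1` reads > 11000 nM, also a limit. Compound 3 therefore has no exact value and stands with the other two: the limit of > 11000 nM in this assay, at which 3 of the 3 values shown sit.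

The next compound, compound 4 `Cc1ccc(S(=O)(=O)N[C@@H](CC(=O)NC(C)(C)C)C(=O)NCCNC(=O)c2ccccc2O)cc1`, has 2-hydroxyphenyl in place of 3,4-difluorophenyl on that carbonyl carbon: 2-hydroxyphenyl in place of 3,4-difluorophenyl on a carbonyl carbon.

The nearest measured exchange is a step that the two limits leave unreadable from compound 2 to compound 3, which also trades a hydroxy-bearing group against 3,4-difluorophenyl. The other two are a step that the two limits leave unreadable from compound 1 to compound 2 and a step that the two limits leave unreadable from compound 1 to compound 3. None of these steps has a readable size, so they set no direction. Among the compounds with values here, since no compound in this small set has yet given a number, the expectation is for no step beyond the usual scatter, and most likely another limit. The expected change is a step that the limit leaves unreadable from compound 3 to compound 4. For compound 4 the estimated value is 14000 nM, with an expected range from 8000 nM to 30000 nM.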

Compound 4, half-maximal effective concentration: > 11000 nM
Compound 4 ended at the assay's limit; the forecaster's own chance of this, stated with the estimate: 85%; the middle value does not contradict the limit.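

In this assay compound 4 reads > 11000 nM as a limit of the assay, not a number. Its steps to compound 1, compound 2 and compound 3 therefore cannot be read, and all four compounds stand together: the limit of > 11000 nM in this assay, at which 4 of the 4 values shown sit.

The compounds shown leave open whether any group on that carbonyl carbon would give an exact value in this assay at all.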